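Aryl Thioether Swap on the Benzamide Core of Compound 1

This account rests on a few compounds, and the source may have more. Where it says the series, first, only, none or still open, it means among the compounds named here.

Measured compounds:
compound 1, `Nc1ccccc1NC(=O)c1ccc(CSc2ccc(Br)cc2)cc1`: 9.96%
compound 2, `Nc1ccccc1NC(=O)/C=C/c1ccc(CSc2cccc(F)c2)cc1`: 7.95%
compound 3, `Nc1ccccc1NC(=O)/C=C/c1ccc(CSc2cccc3ccccc23)cc1`: 11%

All three were tested in a functional assay on HCT-116 cells (Homo sapiens) for inhibition, read by CCK-8 assay, with a stated time of 72 h, tested at 2 uM; on this read-out higher numbers stand for more inhibition of growth at the one concentration tested and lower numbers for less inhibition of growth. Compound 1 gives 9.96% there, and its nearest neighbour is compound 3 with 11%, while compound 2 gives 7.95%; the three values lie within the usual scatter of one another, so no order among them can be claimed.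

The unmeasured compound 4, `Cc1cc(C)cc(SCc2ccc(C(=O)Nc3ccccc3N)cc2)c1`, keeps the core of compound 1 and differs from it in one place: 3,5-dimethylphenyl in place of 4-bromophenyl on a sulfur.

Within the data shown here, only one measured step concerns a change of the aryl group on the sulfur, and it was seen on the longer core shared by compounds 2 and 3: a number 3.1 percentage points higher from compound 2 to compound 3 (within the scatter). That step was within the scatter, and nothing here speaks for a sharper response to the aryl group on the sulfur in this assay .

Compound 4 is therefore expected to give about 10% in this assay , with a range from 2% to 20%. This estimate means a step of a number 0 percentage points higher from compound 1 to compound 4 (within the scatter), expected to stay within the scatter.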

Compound 4, percent growth inhibition at one concentration: 3.22%
Compound 4: the middle estimate sits 6.8 percentage points above what was measured; low and high end bracket the measured number.
By their numbers in this assay, from the lowest: compounds 4, 2, 1 and 3 (each within the scatter of the next).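

On the core of compound 1, the swap of 4-bromophenyl for 3,5-dimethylphenyl on a sulfur whose other neighbour is a saturated chain carbon gives, in this assay, a number 6.7 percentage points lower from compound 1 to compound 4 (within the scatter). Among these compounds, this is the first measured change of the aryl group on the sulfur on this shorter core, and it shows that losing the bromine and gaining two methyl groups there produces no step that can be told from the scatter, just as a number 3.1 percentage points higher from compound 2 to compound 3 (within the scatter) on the longer core stayed within it. No data shown here bear on why the read-out responds this way, and none of the two aryl steps supports a ranking of the aryl groups on the sulfur.

On these data alone, what remains open is whether an aryl group on the sulfur carrying an amine or a carboxylic acid, or a saturated alkyl chain in place of the aryl group, would produce a step beyond the scatter in this assay. As far as these compounds go, whether the two steps seen here would hold at any other concentration also stays open, since each compound is represented by a reading at one concentration only.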